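The source may report more compounds than this note shows. Statements on the series, on what has been measured and on what is new or still open speak of the compounds shown alone.

Series on the shared core of compound 1 `CCc1cc(Br)c(S(C)(=O)=O)cc1C(=O)N=C(N)N`, varied at one aromatic carbon. In a functional assay for inhibition of sodium/hydrogen exchanger (Oryctolagus cuniculus) (a higher number here means a weaker inhibitor, a lower number a stronger inhibitor), compound 1 gives 41 nM. Compound 2 `CCc1cc(N2CCCCC2)c(S(C)(=O)=O)cc1C(=O)N=C(N)N` gives 25 nM, and compound 3 `CCc1cc(N2CCC(O)CC2)c(S(C)(=O)=O)cc1C(=O)N=C(N)N` gives 41 nM. The step of a 1.6-fold lower number from compound 1 to compound 2 (0.21 log units; within the scatter), the step of no change at the digits printed from compound 1 to compound 3 (within the scatter) and the step of a 1.6-fold higher number from compound 2 to compound 3 (0.21 log units; within the scatter) all stay within the scatter; compound 3 is level with compound 1, together the highest of the three numbers, with compound 2 nearest, within the scatter. Compound 4 `CCc1cc(-n2ccc(=O)cc2)c(S(C)(=O)=O)cc1C(=O)N=C(N)N` carries a group of 7 heavy atoms (5 carbon, 1 nitrogen, 1 oxygen; one six-membered aromatic ring with 1 hetero atom) in place of a group of 7 heavy atoms (5 carbon, 1 nitrogen, 1 oxygen; one six-membered non-aromatic ring with 1 hetero atom), on an aromatic carbon. All three measured steps at this carbon stayed within the scatter, so for compound 4 no step beyond the scatter is expected in this assay, a 1.1-fold higher number from compound 3 to compound 4 (0.04 log units; within the scatter). Compound 4 is estimated at 45 nM, range 15 nM to 140 nM.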

Compound 4, half-maximal inhibitory concentration: 930 nM
The estimate for compound 4 lay 21-fold (1.32 log units) below the measured number, outside the stated range (above it).
By their numbers in this assay, from the lowest: compounds 2, 1 and 3 (each within the scatter of the next); then compound 4.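

At this aromatic carbon, the tolerance shared by bromo, piperidin-1-yl and 4-hydroxypiperidin-1-yl does not extend to every group: replacing the 4-hydroxypiperidin-1-yl group with the aromatic ring of equal heavy-atom count gives a 23-fold higher number from compound 3 to compound 4 (1.36 log units; beyond the scatter). The loss also holds against the other two groups, with a 37-fold higher number from compound 2 to compound 4 (1.57 log units; beyond the scatter) and a 23-fold higher number from compound 1 to compound 4 (1.36 log units; beyond the scatter). Nothing available explains it.

Going by these compounds, whether the loss follows the aromatic ring or its carbonyl remains open. Phenyl and pyridin-4-yl at this carbon would separate the two.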